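Replacing the Amide-Bearing Ring in Compound 2

The source may report more compounds than this note shows. Statements on the series, on what has been measured and on what is new or still open speak of the compounds shown alone.

Compound 2 `NC(=O)c1ccc(-c2cnc(C(=O)CCCCCCc3ccccc3)o2)nc1` gives the lowest of the two numbers in an assay (Rattus norvegicus) for inhibition of Fatty-acid amide hydrolase 1 (Homo sapiens) (a higher number here means a weaker inhibitor, a lower number a stronger inhibitor), namely 1.2 nM. Among the compounds with values here, compound 1 `O=C(CCCCCCc1ccccc1)c1ncc(-c2cccc(O)c2)o1` gives 50 nM in this assay, and the single measured step, a 42-fold lower number from compound 1 to compound 2 (1.62 log units; beyond the scatter), accompanied the arrival of 5-carbamoylpyridin-2-yl in place of 3-hydroxyphenyl. Compound 3 `O=C(CCCCCCc1ccccc1)c1ncc(-c2cncnc2)o1` differs from compound 2 in one place: pyrimidin-5-yl in place of 5-carbamoylpyridin-2-yl on an aromatic carbon. The incoming ring carries no hydrogen-bond donor, and since the large gain recorded in a 42-fold lower number from compound 1 to compound 2 (1.62 log units; beyond the scatter) came with the carbamoyl group, compound 3 is expected to give a moderately higher number, a 13-fold higher number from compound 2 to compound 3 (1.10 log units; beyond the scatter). The estimate for compound 3 is 15 nM, with a likely range from 4 nM to 60 nM.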

Compound 3, inhibition constant: 22 nM
Compound 3: the middle estimate sits 1.5-fold (0.17 log units) below what was measured, within the range that was stated.
By their numbers in this assay, from the lowest: compound 2; then compound 3; then compound 1.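

Trading 5-carbamoylpyridin-2-yl for pyrimidin-5-yl gives up most of the earlier gain in this assay, with an 18-fold higher number from compound 2 to compound 3 (1.26 log units; beyond the scatter). Even so, this ring, with 0 hydrogen-bond donors, still improves on 3-hydroxyphenyl at this position, with a 2.3-fold lower number from compound 1 to compound 3 (0.36 log units; beyond the scatter). Nothing measured here explains either step. The compounds shown leave open whether the gain in compound 2 belongs to the carbamoyl group or to the ring that carries it. A nitrile or a carboxylic acid in place of the carbamoyl group would help separate the two.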